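The source may hold more compounds than are shown below. What is called first, only, known or untested is meant among the compounds shown, and "the series" means these compounds.

Compound 1 `COc1cc(CC2C(C#N)=C(N)N(c3ccc(S(N)(=O)=O)cc3)C3=C2C(=O)CCC3)ccc1O` gives 50% in a functional assay on Ehrlich cells (Mus musculus) for antiproliferative activity, read by trypan blue exclusion, with a stated time of 2 h, tested at 25 ug/mL; on this read-out higher numbers stand for a stronger effect at the one concentration tested and lower numbers for a weaker effect. Compound 2 `N#CC1=C(N)N(c2ccc(S(N)(=O)=O)cc2)C2=C(C(=O)CCC2)C1c1ccco1` gives 0% in this assay, the lowest of the two numbers shown, and the only measured step, a number 50 percentage points lower from compound 1 to compound 2 (beyond the scatter), lies beyond the scatter. Compound 3 `Cc1ccoc1C1C(C#N)=C(N)N(c2ccc(S(N)(=O)=O)cc2)C2=C1C(=O)CCC2` differs from compound 2 by methyl in place of hydrogen on an aromatic carbon. Within the data shown here, no measured step concerns this kind of change; the one known step swaps a whole ring for another and offers no guide. The step is therefore expected to be a number 5 percentage points higher from compound 2 to compound 3 (within the scatter), within the scatter. Compound 3 is estimated at 5%, with a range from 0% to 25%.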

Compound 3, a percentage reported as activity, at one concentration (the size of the read-out at that concentration, not a potency): 10%
The estimate for compound 3 lay 5 percentage points below the measured number; measured number inside the range.
By their numbers in this assay, from the lowest: compounds 2 and 3 (each within the scatter of the next); then compound 1.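

In this assay, methyl in place of hydrogen on this aromatic carbon of the furan gives a number 10 percentage points higher from compound 2 to compound 3 (within the scatter), so the added methyl leaves compound 3 within the scatter of compound 2. The 3-methylfuran-2-yl group does not close the gap to the 4-hydroxy-3-methoxybenzyl group, with a number 40 percentage points lower from compound 1 to compound 3 (beyond the scatter) remaining beyond the scatter. No measurement at hand explains either step.

On these data alone, whether an amine, a carboxylic acid or a longer chain on this carbon would read differently stays open. So does which part of the 4-hydroxy-3-methoxybenzyl group goes with the higher number of compound 1.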